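The source may report more compounds than this note shows. Statements on the series, on what has been measured and on what is new or still open speak of the compounds shown alone.

Measured compounds:
- compound 1, `CCC(C)COc1cccc2ccc(N)nc12`: 36 nM
- compound 2, `CC(C)Oc1cccc2ccc(N)nc12`: 437 nM
- compound 3, `CC(COC(C)(C)C)Oc1cccc2ccc(N)nc12`: 306 nM

All three share one core and differ only in the group on an oxygen on an aromatic ring, measured in an assay on cells with melanin-concentrating hormone receptor 1 (Homo sapiens) as the target, read by radioligand binding; a higher number here means a weaker inhibitor, a lower number a stronger inhibitor. Compound 2 has the highest number of the three; compound 3 lies within the scatter of it, while compound 1 sits far lower, as the step of a 12-fold higher number from compound 1 to compound 2 (1.08 log units; beyond the scatter) shows.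

The unmeasured compound 4, `CC(C)(C)CCOc1cccc2ccc(N)nc12`, differs from compound 2 by 3,3-dimethylbutyl in place of isopropyl on an oxygen on an aromatic ring.

Going by the values given here, the step that bears on this is the one from compound 1 to compound 2, where a longer branched chain was replaced by the short isopropyl and the number rose sharply: a 12-fold higher number from compound 1 to compound 2 (1.08 log units; beyond the scatter). Compound 4 brings back a longer branched chain, so a step in the opposite direction, down to a lower number, is expected in this assay, of roughly the same size. The step of a 1.4-fold lower number from compound 2 to compound 3 (0.15 log units; within the scatter) adds little here.

Compound 4 is therefore expected to give about 50 nM, between 15 nM and 170 nM, an estimated step of an 8.7-fold lower number from compound 2 to compound 4 (0.94 log units; beyond the scatter).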

Compound 4, half-maximal inhibitory concentration: 201 nM
Compound 4: the middle estimate sits 4.0-fold (0.60 log units) below what was measured, outside the stated range (above it).
By their numbers in this assay, from the lowest: compound 1; then compounds 4, 3 and 2 (each within the scatter of the next, the first and the last beyond it).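

In this assay, a longer branched chain on this oxygen is not enough by itself to reach the low number of compound 1: 3,3-dimethylbutyl in place of isopropyl gives only a 2.2-fold lower number from compound 2 to compound 4 (0.34 log units; beyond the scatter) and so recovers a small part of the earlier loss. Where the branch lies in the chain also counts here, as neopentyl in place of sec-butyl on the saturated chain carbon bound to the oxygen gives a 5.6-fold higher number from compound 1 to compound 4 (0.75 log units; beyond the scatter) even though both chains are branched. Nothing available here accounts for this difference between the two chains.

The compounds shown leave open how a straight hexyl chain or a cyclohexylmethyl group would behave on this oxygen. They also leave open whether a 3-methylbutyl chain would sit nearer compound 1 or compound 4.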